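Benzyloxy in Place of 4-Hydroxyphenyl in Mice

A few compounds are considered here, and "the series" means these few. Any claim that something is new, unique, unknown or untested is made for them only; others in the source may bear on it.

Measured compounds:
compound 1, `Cc1ccc(CN2C(=O)S/C(=C\c3ccc(N(C)C)cc3)C2=O)cc1`: 14.9%
compound 2, `Cc1ccc(CN2C(=O)S/C(=C\c3ccc(O)cc3)C2=O)cc1`: 19.9%

In a functional assay on the whole organism (plasma) with Mus musculus as the target, with a stated time of 15 days, at a dose of 10 mg/kg by the oral route (a higher number here means a stronger effect of the compound at the dose given, a lower number a weaker effect), compound 1 gives 14.9% and compound 2 gives 19.9%. The step of a number 5 percentage points higher from compound 1 to compound 2 (within the scatter) lies within the scatter. Of the two numbers, compound 2 holds the nominally higher one, but compound 1 sits within the scatter of it. Compound 3 `Cc1ccc(CN2C(=O)S/C(=C\OCc3ccccc3)C2=O)cc1` differs from compound 2 by benzyloxy in place of 4-hydroxyphenyl on a double-bonded chain carbon bound to a double-bonded ring carbon. Within the data shown here, no measured step touches this position, and the single known step of a number 5 percentage points higher from compound 1 to compound 2 (within the scatter) is small, so the expectation rests on compound 2 alone. The expected step of a number 2.9 percentage points lower from compound 2 to compound 3 (within the scatter) is therefore small, with no direction beyond the scatter. Compound 3 is estimated at 17%, with a range from 4% to 32%.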

Compound 3, a percentage reported as activity, at one dose (the size of the read-out at that dose, not a potency): 9.37%
Estimate against measurement, compound 3: 7.6 percentage points above, and the stated range covers the measured number.
By their numbers in this assay, from the lowest: compounds 3, 1 and 2 (each within the scatter of the next, the first and the last beyond it).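

In this assay, this position responds beyond the scatter: benzyloxy in place of 4-hydroxyphenyl gives a number 10.5 percentage points lower from compound 2 to compound 3 (beyond the scatter), a modest step. Among these compounds, the only other step, at an aromatic carbon, stayed within the scatter. No measurement at hand bears on why this change lowers the number.

As far as these compounds go, whether an amine, a carboxylic acid or a longer chain at this position would keep the number of compound 2 remains open. Benzyloxy also brings no hydrogen-bond donor and one more heavy atom, and the compounds shown do not separate these two differences.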